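Removing the pyrimidin-2-yl group from compound 2

This account rests on a few compounds, and the source may have more. Where it says the series, first, only, none or still open, it means among the compounds named here.

In a functional assay on K562 cells (Homo sapiens) for antiproliferative activity, read by sulforhodamine B assay, with a stated time of 72 h (on this read-out higher numbers stand for weaker inhibition and lower numbers for stronger inhibition), compound 2 (`O=S(=O)(Nc1ncccn1)c1ccc(Nc2nncc3ccccc23)cc1`) gives 43 nM and compound 1 (`CCN1C(=O)CS/C1=N/Nc1nncc2ccccc12`) gives 76 nM as two numbers that lie within the usual scatter of each other. Neither compound can therefore be placed ahead of the other. The next compound keeps the rest of compound 2 unchanged. Compound 3 (`NS(=O)(=O)c1ccc(Nc2nncc3ccccc23)cc1`) carries hydrogen in place of pyrimidin-2-yl on a sulfonamide nitrogen. Going by the values given here, the two measured compounds differ in more than one place, so no measured step shows what this change does, and the expectation is only a judgment. A moderate rise in the number, meaning weaker inhibition, is expected (a 2.3-fold higher number from compound 2 to compound 3 (0.37 log units; beyond the scatter)) as an estimate, although a result within the scatter would fit as well. For compound 3 the estimated value is 100 nM within an expected range (30 nM to 350 nM).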

Compound 3, half-maximal inhibitory concentration: 14 nM
Compound 3: the middle estimate sits 7.1-fold (0.85 log units) above what was measured; the whole stated range lies above it.
By their numbers in this assay, from the lowest: compound 3; then compounds 2 and 1 (each within the scatter of the next).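

In this assay the pyrimidin-2-yl group on the sulfonamide nitrogen proves not to be required for activity, as replacing it with hydrogen gives a 3.1-fold lower number from compound 2 to compound 3 (0.49 log units; beyond the scatter) and this modest step lies toward stronger inhibition. Going by these compounds alone, this is the only comparison so far that isolates a single place, and it shows that all the heavy atoms of pyrimidin-2-yl can leave this nitrogen without any loss of activity on this read-out. Nothing measured here accounts for the change.

The compounds shown leave open how other groups on this nitrogen, such as methyl, acetyl or phenyl, would compare with hydrogen and pyrimidin-2-yl. They also leave open whether the same replacement would give a step of similar size on a different core.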